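The source may hold more compounds than are shown below. What is called first, only, known or untested is meant among the compounds shown, and "the series" means these compounds.

Measured compounds:
compound 1, `Cn1c(-c2ccc(Cl)c(Cl)c2)cc2cc(N)ccc21`, 42%
compound 2, `Clc1ccc(-c2cc3ccccc3[nH]2)cc1Cl`, 22.7%
compound 3, `Cn1c(-c2ccc(Cl)c(Cl)c2)cc2ccccc21`, 20%

In an assay on isolated protein for inhibition of Aromatase (Homo sapiens), read by fluorescence, using NADPH, with a stated time of 30 min, tested at 50 uM (on this read-out lower numbers stand for less inhibition and higher numbers for more inhibition at the one concentration tested (going by the name of the read-out)), compound 3 gives the smallest of the three numbers, yet compound 2 is separated from it only by a number 2.7 percentage points lower from compound 2 to compound 3 (within the scatter), a gap within the scatter; the one clear separation is to compound 1, which lies a number 22 percentage points lower from compound 1 to compound 3 (beyond the scatter) away. Compound 4, `Cn1c(-c2ccc(Cl)c(Cl)c2)cc2cc([N+](=O)[O-])ccc21`, differs from compound 3 by nitro in place of hydrogen on an aromatic carbon.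

Among the compounds with values here, of the measured steps, the one from compound 1 to compound 3 is the only one that touches the same aromatic carbon: there the loss of the amino group brought a drop of a number 22 percentage points lower from compound 1 to compound 3 (beyond the scatter), a modest change beyond the scatter. The step from compound 2 to compound 3 concerns the aromatic nitrogen and is within the scatter, so it says little here. Within the data shown here, no measured pair shows a nitro group at this position, so the size of the step to compound 4 cannot be read directly from the data; a substituent on this carbon has so far only been seen to raise the number.

Compound 4 is therefore expected to give 28% in this assay, within 10% to 50%. That estimate corresponds to an expected step of a number 8 percentage points higher from compound 3 to compound 4 (within the scatter), of uncertain direction and possibly within the scatter.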

Compound 4, a percentage reported as inhibition, at one concentration (the size of the read-out at that concentration, not a potency): 34%
Compound 4: the middle estimate sits 6 percentage points below what was measured; low and high end bracket the measured number.
By their numbers in this assay, from the lowest: compounds 3 and 2 (each within the scatter of the next); then compounds 4 and 1 (each within the scatter of the next).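

In this assay, the step of a number 14 percentage points higher from compound 3 to compound 4 (beyond the scatter) shows that the amino group of compound 1 is not the only substituent on this aromatic carbon that lifts the number clear of the scatter above the unsubstituted compound. Exchanging one group for the other gives a number 8 percentage points lower from compound 1 to compound 4 (within the scatter) and so leaves nitro and amino indistinguishable in this read-out, even though the two groups are very different in kind. Since the nitro group counts no hydrogen-bond donors, a donor on this carbon is not needed for the number to rise above that of compound 3, although this rests on a single pair and at a single tested concentration.

The compounds shown leave open whether a small group such as methoxy, fluorine or a carboxylic acid on the same carbon would raise the number as well, and whether nitro or amino would act the same way on the core of compound 2, which carries hydrogen on the aromatic nitrogen. No measurement given here accounts for why either group raises the number.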